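Compound 3 Adds a Trifluoromethyl to Compound 2

The source may hold more compounds than are shown below. What is called first, only, known or untested is meant among the compounds shown, and "the series" means these compounds.

Compound 1 `COc1ccc(/C=C/C2CC(=O)C=CO2)cc1` and compound 2 `O=C1C=CCC(/C=C/c2ccccc2)N1` were both examined in an ADME assay on HaCaT cells (Homo sapiens) for inhibition, read by sulforhodamine B assay, with a stated time of 48 h; a lower number here means a stronger inhibitor of growth, a higher number a weaker inhibitor of growth. In this assay compound 1 gives 145 uM. In this assay compound 2 gives only a limit of the assay, > 1250 uM. Compound 2 therefore stands at the limit of > 1250 uM in this assay, at which 1 of the 2 values shown sits, with no number of its own. Compound 3 `O=C1C=CCC(/C=C/c2ccccc2C(F)(F)F)N1` differs from compound 2 by trifluoromethyl in place of hydrogen on an aromatic carbon. Going by the values given here, no pair of measured compounds shows this change, so its step is unknown; the step is expected to be an at least 1.2-fold lower number from compound 2 to compound 3 (0.09 log units; that floor lies within the scatter), likely within the scatter. Compound 3 is thus estimated at 1000 uM, between 300 uM and 3000 uM.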

Compound 3, concentration for growth inhibition (reported as GI): 249 uM
Beside the measured number, compound 3's estimate is 4.0-fold (0.60 log units) above it, and the stated range ends above it.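

In this assay, trifluoromethyl in place of hydrogen on an aromatic carbon gives an at least 5.0-fold lower number from compound 2 to compound 3 (0.70 log units; beyond the scatter). This shows that this position of the six-membered aromatic ring can take a substituent with a measurable gain in growth inhibition. Going by these compounds, the full size of the step stays unknown, because it rests on a limit of the assay for compound 2: the limit of > 1250 uM in this assay, at which 1 of the 3 values shown sits.

On these data alone, whether an amine or a nitrile in the same place would lower the number as far remains open. So does whether trifluoromethyl would do the same elsewhere on this ring.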